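The compounds below may be only part of what the source reports. "The series", "measured", "known", "first", "only" and "open" are said of these compounds alone.

In a functional assay on T47D cells (Homo sapiens) for cytotoxicity, read by MTT assay, with a stated time of 48 h (on this read-out lower numbers stand for stronger inhibition and higher numbers for weaker inhibition), compound 3 `S=C(N/N=C\c1ccnc2ccccc12)Nc1ccccc1` gives 1380 nM, compound 1 `CCc1ccc(NC(=S)N/N=C\c2ccnc3ccccc23)cc1` gives 1280 nM and compound 2 `O=[N+]([O-])c1ccc(NC(=S)N/N=C\c2ccnc3ccccc23)cc1` gives 1330 nM, so compound 3 stands level with both within the scatter. Compound 4 `Cc1ccc(NC(=S)N/N=C\c2ccnc3ccccc23)cc1` has methyl in place of hydrogen on an aromatic carbon, para to a large group: methyl in place of hydrogen on an aromatic carbon. Within the data shown here, three measured steps bear on this change: a 1.1-fold higher number from compound 1 to compound 3 (0.03 log units; within the scatter), a 1.0-fold higher number from compound 2 to compound 3 (0.02 log units; within the scatter) and a 1.0-fold higher number from compound 1 to compound 2 (0.02 log units; within the scatter). All three lie within the scatter, so no step beyond the scatter is expected in this assay, and no direction is expected either. The expected change is a 1.1-fold lower number from compound 3 to compound 4 (0.03 log units; within the scatter). For compound 4 the estimate is 1300 nM, with an expected range of 800 nM to 2100 nM.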

Compound 4, half-maximal inhibitory concentration: 1320 nM
Compound 4: the middle estimate sits 1.0-fold (0.01 log units) below what was measured; the measured number falls inside the stated range.
By their numbers in this assay, from the lowest: compounds 1, 4, 2 and 3 (each within the scatter of the next).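

Methyl on this aromatic carbon, para to a large group, stays level with each of the three other groups in this assay: with hydrogen (a 1.0-fold lower number from compound 3 to compound 4 (0.02 log units; within the scatter)), with nitro (a 1.0-fold lower number from compound 2 to compound 4 (0.00 log units; within the scatter)) and with ethyl (a 1.0-fold higher number from compound 1 to compound 4 (0.01 log units; within the scatter)). The last of these steps shortens the chain by one carbon and also stays within the scatter, so the four compounds give no order at this position. No measurement at hand bears on why these values stay level.
From the compounds shown here alone, whether an amine, a carboxylic acid or a longer chain at this position would stay level remains open.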